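The source may hold more compounds than are shown below. What is called first, only, known or untested is meant among the compounds shown, and "the series" means these compounds.

Measured so far: compound 1 `O=c1ccc2cc(OCc3cc(-c4ccccc4Cl)no3)ccc2o1` with 18200 nM; compound 2 `O=c1ccc2cc(OCc3cc(-c4cccc(Cl)c4)no3)ccc2o1` with "not determined" (no result reported).

In a functional assay on PC-3 cells (Homo sapiens) for cytotoxicity, read by MTT assay, with a stated time of 48 h (on this read-out lower numbers stand for stronger inhibition and higher numbers for weaker inhibition), compound 1 gives 18200 nM, a weak result. Compound 2 carries no number in this assay; for compound 2 the record reads "not determined" (no result reported), so there is nothing to say where it stands. Compound 3 `O=c1ccc2cc(OCc3cc(-c4ccccc4[N+](=O)[O-])no3)ccc2o1` differs from compound 2 by 2-nitrophenyl in place of 3-chlorophenyl on an aromatic carbon. Going by the values given here, with no measured pair to set a scale, no shift beyond the usual scatter is expected from this exchange. Compound 1 with 18200 nM is the only anchor, and its weak potency frames the guess. Compound 3 is expected to give 20000 nM in this assay, within a range from 5000 nM to 80000 nM.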

Compound 3, half-maximal inhibitory concentration: 8200 nM
Compound 3: middle estimate off by 2.4-fold (0.39 log units), on the high side, within the range that was stated.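

In this assay, nitro in place of chloro on an aromatic carbon brings a 2.2-fold lower number from compound 1 to compound 3 (0.35 log units; beyond the scatter). Going by these compounds alone, this is the first sign that the group at this place can move the number beyond the usual scatter, though the step is modest. No measurement shown here explains the shift.

The step from compound 2 to compound 3 cannot be read, since compound 2 has no number. On these data alone, whether an amine or a carboxylic acid on this aromatic carbon would move the number further, and in which direction, remains open.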